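The source may report more compounds than this note shows. Statements on the series, on what has been measured and on what is new or still open speak of the compounds shown alone.

In a functional assay on K562 cells (Homo sapiens) for antiproliferative activity, read by MTT assay (a lower number here means a stronger inhibitor, a higher number a weaker inhibitor), compound 1 `O=C1NC(c2ccccc2)CN1S(=O)(=O)c1ccc2c(c1)CCCN2` gives > 20000 nM, which is a limit of the assay and not a number. Going by the values given here, compound 2 `CCCCOC(=O)N1CCCc2cc(S(=O)(=O)N3CC(c4ccccc4)NC3=O)ccc21`, with butoxycarbonyl in place of hydrogen on a nitrogen, gives 3680 nM, the only true number so far. The measured result of that swap is an at least 5.4-fold lower number from compound 1 to compound 2 (0.73 log units; beyond the scatter), a step beyond the scatter. Compound 3 `O=C(OCCCl)N1CCCc2cc(S(=O)(=O)N3CC(c4ccccc4)NC3=O)ccc21` keeps this group but alters its far end: chloro in place of ethyl on a saturated chain carbon, two bonds along the chain from an oxygen next to a carbonyl group. This places chloro in place of ethyl on a saturated chain carbon, two bonds along the chain from an oxygen next to a carbonyl group, so butoxy becomes 2-chloroethoxy. Among the compounds with values here, the one measured step added the whole group, so it sets no size for this smaller edit. No shift beyond the scatter is expected, and the estimated step is a 1.2-fold lower number from compound 2 to compound 3 (0.09 log units; within the scatter). For compound 3 the estimate is 3000 nM, with an expected range from 1000 nM to 9000 nM.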

Compound 3, half-maximal inhibitory concentration: 10600 nM
Beside the measured number, compound 3's estimate is 3.5-fold (0.55 log units) below it, outside the stated range (above it).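

In this assay, the far end of this group matters and not only its presence on the nitrogen: butoxy to 2-chloroethoxy gives a 2.9-fold higher number from compound 2 to compound 3 (0.46 log units; beyond the scatter). Against hydrogen on that nitrogen, the 2-chloroethoxycarbonyl group gives an at least 1.8-fold lower number from compound 1 to compound 3 (0.27 log units; that floor lies within the scatter), so a clear gain cannot be claimed for it, as it can for butoxycarbonyl. Compound 1 stands at a limit of the assay and not at a number, so that step is only a floor: the limit of > 20000 nM in this assay, at which 1 of the 3 values shown sits.

The edit removes ethyl and brings in chloro at once, so these compounds cannot say whether the weaker result follows from losing chain carbons or from gaining the chlorine. As far as these compounds go, how a plain ethoxy group, a longer chain such as hexyloxy, or an amine at the far end of the chain would read in this assay also stays open.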